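Urea in Place of Cyclobutyl Amide on a Soluble Scaffold

This account rests on a few compounds, and the source may have more. Where it says the series, first, only, none or still open, it means among the compounds named here.

Measured compounds:
compound 1, `CC(C)(C)C(=O)N1Cc2c(NC(=O)c3cccnc3)n[nH]c2C1(C)C`, solubility 207000 nM
compound 2, `CN1CCC(C(=O)N2Cc3c(NC(=O)C4CCC4)n[nH]c3C2(C)C)CC1`, solubility > 225000 nM

Two compounds share the same core. In a physicochemical assay for solubility, at pH 7 (a higher number here means a more soluble compound, a lower number a less soluble compound), compound 1 gives 207000 nM. For compound 2 this assay reports only a limit, > 225000 nM, so compound 2 stands at the upper edge of what this assay can report (the limit of > 225000 nM in this assay, at which 1 of the 2 values shown sits). The new compound 3, `CCCNC(=O)Nc1n[nH]c2c1CN(C(=O)C1CCN(C)CC1)C2(C)C`, keeps the rest of compound 2 unchanged and differs in one place: propylamino in place of cyclobutyl on a carbonyl carbon. Among the measured compounds shown here, no measured pair shows the effect of this change, so the account rests on compound 2 alone. Since compound 2 already sits at the limit > 225000 nM, compound 3 is expected to show no step beyond the scatter in this assay, a number no higher from compound 2 to compound 3 (the limit leaves the size open). Compound 3 is therefore estimated at 225000 nM, within 110000 nM to 300000 nM, with a fair chance that this assay again reports only a limit.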

Compound 3, solubility: > 225000 nM
Compound 3 was reported as a limit; the forecaster's own chance of this, stated with the estimate: 65%; the middle value sits exactly at the limit.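

In this assay compound 3 gives only a limit of > 225000 nM and compound 2 also gives only a limit, so no step can be read between them: the limit of > 225000 nM in this assay, at which 2 of the 3 values shown sit.

As far as these compounds go, what stays open is how far compound 2 and compound 3 lie past the limit in this assay and whether propylamino in place of cyclobutyl on a carbonyl carbon shifts the read-out at all.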